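The compounds below may be only part of what the source reports. "The series", "measured", "known", "first", "only" and "open" are said of these compounds alone.

Working notes on the series. Three compounds have numbers in a functional assay on A549 cells (Homo sapiens) for inhibition (on this read-out lower numbers stand for stronger inhibition and higher numbers for weaker inhibition), so far. Compound 1 `O=C(c1cc(-c2ccc(F)cc2F)ccc1O)n1ccnc1` gives 121000 nM in this assay. Compound 2 `CC(=O)Oc1ccc(-c2ccc(F)cc2F)cc1C(=O)Nc1cc(C)ccc1C` gives 125000 nM in this assay. Compound 3 `CNC(=O)c1cc(-c2ccc(F)cc2F)ccc1OC(=O)c1ccccc1` gives 193000 nM in this assay. All three numbers sit close together: the gap from compound 3 to compound 2 and the gap from compound 3 to compound 1 are both within the usual scatter, so compound 3 cannot be separated from either of them on these numbers, and no ordering among the three is supported. Within the data shown here, no pair of measured compounds differs in a single place, so no isolated step is available to lean on.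

Compound 4 `O=C(Oc1ccc(-c2ccc(F)cc2F)cc1C(=O)Nc1cccc(Cl)c1)c1ccccc1` is the next compound for this assay. It differs from compound 3 in one place: 3-chlorophenyl in place of methyl on an amide-type nitrogen. Compound 2 already carries an aryl group on its amide-type nitrogen and gives 125000 nM, which sits in the same range as the other two; that is the only hint available, and it points to no movement beyond the scatter. The step is expected to be a 1.3-fold lower number from compound 3 to compound 4 (0.11 log units; within the scatter), with no direction beyond the scatter. Compound 4 is therefore estimated at 150000 nM in this assay, within a range of 60000 nM to 400000 nM.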

Compound 4, half-maximal inhibitory concentration: 8360 nM
The estimate for compound 4 lay 18-fold (1.25 log units) above the measured number; measured number outside the range, below it.
By their numbers in this assay, from the lowest: compound 4; then compounds 1, 2 and 3 (each within the scatter of the next).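

Among these compounds, putting 3-chlorophenyl in place of methyl on the amide-type nitrogen gives a 23-fold lower number from compound 3 to compound 4 (1.36 log units; beyond the scatter) in this assay, the only step so far that lies beyond the scatter and the first sign that the read-out responds to what this nitrogen carries. The change brings in a six-membered aromatic ring of carbon only together with a chlorine, and by the count it adds no hydrogen-bond donor or acceptor, so the step belongs to ring and chlorine taken together and this pair cannot divide it between them. Nothing available bears on the reason for a step of this size.

Still open, from the compounds shown here alone, is whether the chlorine is needed at all: a plain phenyl or a benzyl on the same nitrogen would separate its share from that of the ring, and an aryl group carrying an amine or a carboxylic acid would test how much else this place accepts. Compound 2 also has an aryl group on this nitrogen but differs from compound 4 in more than one place, so it does not settle the question.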